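Amide aryl variation on the shared core

A few compounds are considered here, and "the series" means these few. Any claim that something is new, unique, unknown or untested is made for them only; others in the source may bear on it.

For the measured compounds named here, compound 2 `O=C(Nc1cccc(-c2oc3cc(-c4ccc(F)cc4)ccc3c(=O)c2O)c1)c1ccc(Br)cc1` gives 24000 nM in a functional assay on MCF7 cells (Homo sapiens) for antiproliferative activity, read by CCK-8 assay, with a stated time of 72 h (a lower number here means a stronger inhibitor, a higher number a weaker inhibitor), the highest of the two numbers so far; its nearest neighbour, compound 1 `Cc1ccccc1C(=O)Nc1cccc(-c2oc3cc(-c4ccc(F)cc4)ccc3c(=O)c2O)c1`, gives 2280 nM. Going by the values given here, the single measured step, an 11-fold higher number from compound 1 to compound 2 (1.02 log units; beyond the scatter), is large. Compound 3 `Cc1cc(C(=O)Nc2cccc(-c3oc4cc(-c5ccc(F)cc5)ccc4c(=O)c3O)c2)ccc1F` differs from compound 2 by 4-fluoro-3-methylphenyl in place of 4-bromophenyl on a carbonyl carbon. Among the compounds with values here, no measured step covers this exact exchange; the only guide is that large step, whose starting group, 2-methylphenyl, also carries a methyl. A moderate move toward a lower number is therefore expected, a 3.0-fold lower number from compound 2 to compound 3 (0.48 log units; beyond the scatter). Compound 3 is estimated at 8000 nM, with a range of 2000 nM to 30000 nM.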

Compound 3, half-maximal inhibitory concentration: 7710 nM
Beside the measured number, compound 3's estimate is 1.0-fold (0.02 log units) above it, and the stated range covers the measured number.
By their numbers in this assay, from the lowest: compound 1; then compound 3; then compound 2.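

On the carbonyl carbon, 4-fluoro-3-methylphenyl in place of 4-bromophenyl gives a 3.1-fold lower number from compound 2 to compound 3 (0.49 log units; beyond the scatter), so a halogen on this aryl group does not by itself fix the number at the level of compound 2. The same group in place of 2-methylphenyl gives a 3.4-fold higher number from compound 1 to compound 3 (0.53 log units; beyond the scatter), so compound 1 remains the lowest of the three. No other data on the series bear on either step.

Going by these compounds, the aryl groups of compound 2 and compound 3 differ in more than one substituent, and the share of each stays open. On these data alone, how an amine or a carboxylic acid on this aryl ring would read also remains open.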